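The source may hold more compounds than are shown below. What is called first, only, known or untested is meant among the compounds shown, and "the series" means these compounds.

Compound 1 `O=C(NCc1ccc(S(=O)(=O)N2CCCCC2)cc1)c1cc2ccncc2[nH]1` was tested in a functional assay on A2780 cells (Homo sapiens) for inhibition, read by sulforhodamine B assay, with a stated time of 72 h (a lower number here means a stronger inhibitor, a higher number a weaker inhibitor), where compound 1 gives 1700 nM. Going by the values given here, of the two numbers measured so far this is the highest. Among the compounds with values here, the only companion, compound 2 `O=C(NCc1ccc(S(=O)(=O)c2ccccc2)cc1)c1cc2ccncc2s1`, differs from compound 1 both in its bicyclic core and in the group attached to the sulfonyl, and in this assay compound 2 gives 14 nM, a far lower number; with two changes at once, the pair shows only that the number can move a long way, not which change moves it.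

The account now turns to compound 3 `O=C(NCc1ccc(S(=O)(=O)N2CCCCC2)cc1)c1cc2cnccc2o1`, which keeps the piperidine sulfonamide side of compound 1 and alters only the core. The difference is a group of 9 heavy atoms (7 carbon, 1 nitrogen, 1 oxygen; one five-membered aromatic ring with 1 hetero atom, one six-membered aromatic ring with 1 hetero atom) in place of a group of 9 heavy atoms (7 carbon, 2 nitrogen; one five-membered aromatic ring with 1 hetero atom, one six-membered aromatic ring with 1 hetero atom), on a carbonyl carbon. Within the data shown here, no measured pair isolates a core exchange of this kind, so the size of the step is uncertain. The value of compound 2 14 nM shows that a different core is compatible with strong inhibition. A downward step of moderate size is expected, a 2.8-fold lower number from compound 1 to compound 3 (0.45 log units; beyond the scatter), though a result within the scatter would not surprise. For compound 3 the estimate in this assay is 600 nM, with a range from 150 nM to 3000 nM.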

Compound 3, half-maximal inhibitory concentration: 1500 nM
Compound 3: middle estimate off by 2.5-fold (0.40 log units), on the low side, within the range that was stated.
By their numbers in this assay, from the lowest: compound 2; then compounds 3 and 1 (each within the scatter of the next).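

In this assay, going by these compounds alone, with the piperidine sulfonamide side held fixed, the exchange on the carbonyl carbon gives a 1.1-fold lower number from compound 1 to compound 3 (0.05 log units; within the scatter) and is the first step here that isolates a single place. The group that leaves carries 1 hydrogen-bond donor and 1 hydrogen-bond acceptor and the group that enters 0 hydrogen-bond donors and 2 hydrogen-bond acceptors, yet the step stays within the scatter, so for this pair the exchange of one core for the other, with the loss of that donor, leaves the reading unchanged. No measurement shown here bears on why the two compounds read alike.

Going by these compounds, compound 2, at 14 nM, differs from compound 1 and from compound 3 in both the core and the group attached to the sulfonyl, so it remains open how much of its low number belongs to either change, and the phenyl group on the core of compound 1 or of compound 3 would be needed to separate them. Also open, on these data alone, is whether a morpholine in place of the piperidine, or a simple amine, would move the number at all.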